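A few compounds are considered here, and "the series" means these few. Any claim that something is new, unique, unknown or untested is made for them only; others in the source may bear on it.

Compound 3, `CS(=O)(=O)c1ccc(N2N=C(c3ccc(Cl)cc3)CCC2=O)cc1`, sits at the bottom of the three numbers recorded so far. In a functional assay on the whole organism (strain Wistar) for inhibition, with Rattus norvegicus as the target, read by paw edema, with stated times of 30 min and 3 h, at a dose of 0.05 mmol/kg by the oral route (on this read-out higher numbers stand for more inhibition at the one dose given (going by the name of the read-out) and lower numbers for less inhibition), compound 3 gives 26.6%, whereas compound 1, `Cc1ccc(C2=NN(c3ccc(S(C)(=O)=O)cc3)C(=O)CC2)cc1`, gives 46.7% and compound 2, `CCc1ccc(C2=NN(c3ccc(S(C)(=O)=O)cc3)C(=O)CC2)cc1`, gives 46.7%. The two steps leading to compound 3 were each a number 20.1 percentage points lower from compound 1 to compound 3 (beyond the scatter) and a number 20.1 percentage points lower from compound 2 to compound 3 (beyond the scatter), so exchanging methyl or ethyl for chloro on that aromatic carbon cost a modest but real amount, while no change at the digits printed from compound 1 to compound 2 (within the scatter).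

Compound 4, `CS(=O)(=O)c1ccc(N2N=C(c3ccc(Oc4ccccc4)cc3)CCC2=O)cc1`, is the next case: phenoxy in place of chloro on an aromatic carbon. Among the compounds with values here, no measured pair involves a phenoxy, so the only guidance is that the chloro compound scored lowest and both alkyl compounds scored higher at the same carbon, para to a large group. Compound 4 is therefore expected to recover some ground, an estimated a number 13.4 percentage points higher from compound 3 to compound 4 (beyond the scatter), though with wide uncertainty. For compound 4 the estimate in this assay is 40%, within a range from 20% to 60%.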

Compound 4, a percentage reported as inhibition, in the whole organism at one dose (the size of the read-out at that dose, not a potency): 50%
Estimate against measurement, compound 4: 10 percentage points below; low and high end bracket the measured number.
By their numbers in this assay, from the lowest: compound 3; then compounds 1, 2 and 4 (each within the scatter of the next).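

In this assay, phenoxy in place of chloro on this aromatic carbon, para to a large group, gave a number 23.4 percentage points higher from compound 3 to compound 4 (beyond the scatter), so the position accepts a group of 7 heavy atoms carrying a six-membered aromatic ring with no loss. Phenoxy in place of ethyl gave a number 3.3 percentage points higher from compound 2 to compound 4 (within the scatter), and phenoxy in place of methyl gave a number 3.3 percentage points higher from compound 1 to compound 4 (within the scatter), so these three groups cannot be told apart at this dose and compound 3 alone stands lowest. No measurement shown explains why chloro stands apart from the other three groups.

Going by these compounds, whether another halogen such as fluoro or bromo would match chloro remains open, and so does how an amine or a carboxylic acid would fare at this carbon. A further open point is whether a substituent on the ring of the phenoxy would move the number.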